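Extending the Chain of Compound 2 into an Amide

The source may report more compounds than this note shows. Statements on the series, on what has been measured and on what is new or still open speak of the compounds shown alone.

Of the compounds shown here, three that share one core have been measured in an assay on isolated protein (Oryctolagus cuniculus) with Thromboxane-A synthase (Homo sapiens) as the target, tested at 1 uM; a lower number here means less inhibition, a higher number more inhibition at the concentration tested (going by the name of the read-out). Compound 1 `CCn1nc(-c2cccnc2)c2ccccc2c1=O` gives 87% there. Compound 2 `CCCCn1nc(-c2cccnc2)c2ccccc2c1=O` gives 91%, and compound 3 `O=C(O)CCCn1nc(-c2cccnc2)c2ccccc2c1=O` gives 73%. Compound 2 holds the highest of the three numbers; its gap to compound 1, a number 4 percentage points higher from compound 1 to compound 2 (within the scatter), lies within the scatter, so no order between those two can be read, while the drop a number 18 percentage points lower from compound 2 to compound 3 (beyond the scatter) lies beyond the scatter, as does a number 14 percentage points lower from compound 1 to compound 3 (beyond the scatter).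

Compound 4 `CC(C)NC(=O)CCCn1nc(-c2cccnc2)c2ccccc2c1=O` has not yet been measured in this assay. Relative to compound 2 the change is isopropylcarbamoyl in place of methyl on a saturated chain carbon, three bonds along the chain from an aromatic nitrogen. Among the compounds with values here, the one measured step at the same place on the chain is a number 18 percentage points lower from compound 2 to compound 3 (beyond the scatter), where carboxy entered in place of methyl and the number fell modestly; the step of a number 14 percentage points lower from compound 1 to compound 3 (beyond the scatter), which brought carboxymethyl onto the chain, points the same way. Within the data shown here, no measured step introduces an isopropylcarbamoyl group, so the only guide is that the one group so far placed at this point beyond methyl lowered the number modestly. Compound 4 is therefore expected to lie lower, by an estimated step of a number 11 percentage points lower from compound 2 to compound 4 (beyond the scatter), giving an estimate of 80% with a range from 62% to 92%.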

Compound 4, a percentage reported as inhibition, at one concentration (the size of the read-out at that concentration, not a potency): 89%
The estimate for compound 4 lay 9 percentage points below the measured number, within the range that was stated.
By their numbers in this assay, from the lowest: compound 3; then compounds 1, 4 and 2 (each within the scatter of the next).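

In this assay, a number 2 percentage points lower from compound 2 to compound 4 (within the scatter) shows that isopropylcarbamoyl in place of methyl, on a saturated chain carbon three bonds along the chain from an aromatic nitrogen, leaves no readable change, and a number 2 percentage points higher from compound 1 to compound 4 (within the scatter) likewise shows none against the shorter ethyl compound. The fall seen earlier with the carboxy group therefore does not extend to every group placed at this point on the chain, and a number 16 percentage points higher from compound 3 to compound 4 (beyond the scatter) separates the acid from the amide through a single exchange, isopropylamino in place of hydroxy on a carbonyl carbon. Nothing available gives a cause for this difference between the acid and the amide.

The compounds shown leave open whether a primary amide, a methyl ester or a longer chain ending in the same isopropylcarbamoyl group would also stay level with compound 2. As the read-out comes from one concentration and is not a potency, they also leave open whether compounds 1, 2 and 4 would separate at a lower concentration.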